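The source may hold more compounds than are shown below. What is called first, only, known or untested is meant among the compounds shown, and "the series" means these compounds.

Measured so far in a functional assay (Cavia porcellus) with sulfonylurea receptors; K-ATP channels (Homo sapiens) as the target; on this read-out higher numbers stand for weaker inhibition and lower numbers for stronger inhibition:
compound 1 `CC(O)(C(=O)Nc1ccc(S(=O)(=O)c2ccccc2F)cc1)C(F)(F)F` gives 1300 nM
compound 2 `CC(O)(C(=O)Nc1ccc(S(=O)(=O)c2cccc(O)c2)cc1)C(F)(F)F` gives 18000 nM
compound 3 `COc1ccc(S(=O)(=O)c2ccc(NC(=O)C(C)(O)C(F)(F)F)cc2)cc1` gives > 30000 nM

Compound 3 stands at the edge of what this assay reports: its value is a limit of the assay and not a number, as the limit of > 30000 nM in this assay, at which 1 of the 3 values shown sits, records. Compound 1 and compound 2 both give numbers, and the steps between the three differ only in the aryl group on the sulfonyl sulfur: a 14-fold higher number from compound 1 to compound 2 (1.14 log units; beyond the scatter); an at least 23-fold higher number from compound 1 to compound 3 (1.36 log units; beyond the scatter); an at least 1.6-fold higher number from compound 2 to compound 3 (0.22 log units; that floor lies within the scatter).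

Compound 4 `CC(O)(C(=O)Nc1ccc(S(=O)(=O)c2cccc(Cl)c2)cc1)C(F)(F)F` is the next step from compound 3: 3-chlorophenyl in place of 4-methoxyphenyl on a sulfonyl sulfur. Among the compounds with values here, two measured steps bear on it. Within the data shown here, the one that leads into compound 3, an at least 23-fold higher number from compound 1 to compound 3 (1.36 log units; beyond the scatter), was large, and the one from compound 2, an at least 1.6-fold higher number from compound 2 to compound 3 (0.22 log units; that floor lies within the scatter), has a floor that lies within the scatter. No measured compound carries a chlorine, so the 3-chlorophenyl group itself is untested; the only halogen present, on compound 1, goes with the lowest number shown. Reversing the methoxy step, the number for compound 4 is expected to come down, with an at least 6.0-fold lower number from compound 3 to compound 4 (0.77 log units; beyond the scatter) the estimated step, though the limit on compound 3 leaves its true size open. Compound 4 is estimated at 5000 nM, expected between 1500 nM and 20000 nM.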

Compound 4, half-maximal inhibitory concentration: 10000 nM
For compound 4 the middle estimate is 2.0-fold (0.30 log units) below the measured one; measured number inside the range.
By their numbers in this assay, from the lowest: compound 1; then compounds 4 and 2 (each within the scatter of the next). At a limit, above all of these: compound 3.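

In this assay, the 3-chlorophenyl group on the sulfonyl sulfur gives a 7.7-fold higher number from compound 1 to compound 4 (0.89 log units; beyond the scatter), so carrying a halogen does not alone match compound 1, and chloro in place of hydroxy on an aromatic carbon gives a 1.8-fold lower number from compound 2 to compound 4 (0.26 log units; within the scatter), leaving those two groups unseparated here. Against the 4-methoxyphenyl group, the change reads only as a floor, an at least 3.0-fold lower number from compound 3 to compound 4 (0.47 log units; beyond the scatter), which places the 3-chlorophenyl group clear of that limit but says nothing of the full size. Compound 3 has a limit of the assay and not a number: the limit of > 30000 nM in this assay, at which 1 of the 4 values shown sits.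

Going by these compounds, whether a nitrile or an amine in place of the chloro would bring the number nearer to that of compound 1 stays open. Also open, on these data alone, is whether the low number of compound 1 goes with the fluoro group itself or with the place it holds.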